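Side-chain swaps on the saturated ring: triazolylethyl to carbamoylmethyl

The source may report more compounds than this note shows. Statements on the series, on what has been measured and on what is new or still open speak of the compounds shown alone.

Measured in a functional assay on LNCaP cells (Homo sapiens) for antiproliferative activity (a lower number here means a stronger inhibitor, a higher number a weaker inhibitor), so far
- compound 1 `Cn1ncc(Cl)c1-c1cc(C(=O)N[C@@H]2CN[C@H](CC(O)CO)C[C@H]2c2ccc(Cl)c(Cl)c2)oc1Cl` gives 70 nM
- compound 2 `Cn1ncc(Cl)c1-c1cc(C(=O)N[C@@H]2CN[C@H](CCn3cncn3)C[C@H]2c2ccc(Cl)c(Cl)c2)oc1Cl` gives 60 nM

Among the compounds with values here, compound 2 stands level with compound 1, the only other measured compound, since a 1.2-fold lower number from compound 1 to compound 2 (0.07 log units; within the scatter) is within the scatter. The next compound is compound 3 `Cn1ncc(Cl)c1-c1cc(C(=O)N[C@@H]2CN[C@H](CC(N)=O)C[C@H]2c2ccc(Cl)c(Cl)c2)oc1Cl`, with carbamoyl in place of (1H-1,2,4-triazol-1-yl)methyl on a saturated chain carbon bound to a saturated ring carbon, as counted in carbamoyl in place of (1H-1,2,4-triazol-1-yl)methyl on a saturated chain carbon bound to a saturated ring carbon for this change. That one measured step bears on the swap, and it involves no carbamoyl group, so the evidence is thin. Nothing beyond the scatter is therefore expected in this assay, and the expected step is a 1.5-fold higher number from compound 2 to compound 3 (0.18 log units; within the scatter) at the middle of the estimate. For compound 3 the estimated value is 90 nM within an expected range of 35 nM to 230 nM in this read-out.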

Compound 3, half-maximal inhibitory concentration: 160 nM
For compound 3 the middle estimate is 1.8-fold (0.25 log units) below the measured one; measured number inside the range.
By their numbers in this assay, from the lowest: compounds 2 and 1 (each within the scatter of the next); then compound 3.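

In this assay this side-chain position had not yet separated any compounds, since a 1.2-fold lower number from compound 1 to compound 2 (0.07 log units; within the scatter) stays within the scatter. Carbamoyl is the first change here to move the number beyond the scatter, with a 2.7-fold higher number from compound 2 to compound 3 (0.43 log units; beyond the scatter) and a 2.3-fold higher number from compound 1 to compound 3 (0.36 log units; beyond the scatter) both modest, so the position is not indifferent to what it carries, although the loss is small. No accompanying measurement accounts for this step.

The compounds shown do not settle whether the step follows the carbamoyl group itself or the drop in heavy atoms, from 6 in (1H-1,2,4-triazol-1-yl)methyl to 3 in carbamoyl. A longer chain ending in the same carbamoyl group, or a carboxylic acid or primary amine on the same saturated chain carbon, would help separate these two readings.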